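The compounds below may be only part of what the source reports. "The series", "measured", "known", "first", "only" and "open" are said of these compounds alone.

Measured so far:
- compound 1 `COc1cc(-n2cnc3ccc(-c4ccc([N+](=O)[O-])cc4)cc32)cc(OC)c1OC`: 8940 nM
- compound 2 `COc1cc(-n2cnc3ccc(-c4ccc(C(F)(F)F)cc4)cc32)cc(OC)c1OC`: 3390 nM

Both numbers come from a functional assay on A549 cells (Homo sapiens) for antiproliferative activity, read by MTT assay, with a stated time of 72 h; a lower number here means a stronger inhibitor, a higher number a weaker inhibitor. Compound 1 stands highest of the two numbers; its nearest neighbour is compound 2, reached by a 2.6-fold lower number from compound 1 to compound 2 (0.42 log units; beyond the scatter), a step that exchanges one group on the same aromatic carbon of the shared core.

Compound 3 `COc1ccc(-c2ccc3ncn(-c4cc(OC)c(OC)c(OC)c4)c3c2)cc1` differs from compound 1 as follows: methoxy in place of nitro on an aromatic carbon. Going by the values given here, the only measured step that bears on this change is the one from compound 1 to compound 2, where another group took the place of nitro at this same position and the number fell by a 2.6-fold lower number from compound 1 to compound 2 (0.42 log units; beyond the scatter). Among the compounds with values here, no measured pair shows methoxy against nitro or against trifluoromethyl, so the direction for compound 3 rests on that single step and is not secure. Replacing nitro is expected to move the number modestly downward, by about a 1.8-fold lower number from compound 1 to compound 3 (0.25 log units; within the scatter).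

Compound 3 is therefore expected to give 5000 nM in this assay, with a range from 2000 nM to 13000 nM.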

Compound 3, half-maximal inhibitory concentration: > 10000 nM
Compound 3: a limit, no number (the forecaster's own chance of this, stated with the estimate: 5%); middle value at least 2.0-fold (0.30 log units) away from the limit.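

In this assay compound 3 gives > 10000 nM, which is a limit of the assay and not a number. The position therefore does not reward every replacement of nitro: the trifluoromethyl of compound 2 is the only group shown with a measured gain over nitro, and methoxy in its place gives an at least 2.9-fold higher number from compound 2 to compound 3 (0.46 log units; beyond the scatter), a step beyond the scatter that shows the group at this position matters in either direction. The change from 4-nitrophenyl to 4-methoxyphenyl reads as an at least 1.1-fold higher number from compound 1 to compound 3 (0.04 log units; that floor lies within the scatter), and with that floor within the scatter this step alone fixes no order between the two groups.

Going by these compounds, how far compound 3 lies past its limit stays open, and with it the true size of both steps: the limit of > 10000 nM in this assay, at which 1 of the 3 values shown sits. Also open, on these data alone, is how an amine, a carboxylic acid or a longer chain such as ethoxy would read at this position, so three groups on the shared core support no general rule for it.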